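This account rests on a few compounds, and the source may have more. Where it says the series, first, only, none or still open, it means among the compounds named here.

In a functional assay on DLD-1 cells (Homo sapiens) for cytotoxicity, read by MTT assay (on this read-out higher numbers stand for weaker inhibition and lower numbers for stronger inhibition), compound 1 (`COc1cc(/C=C/C(=O)C(=Cc2ccccc2)C(=O)/C=C/c2ccc(O)c(OC)c2)ccc1O`) gives 5450 nM, compound 2 (`CCOc1cc(C=C(C(=O)/C=C/c2ccc(O)c(OCC)c2)C(=O)/C=C/c2ccc(O)c(OCC)c2)ccc1O`) gives 1360 nM and compound 3 (`CCOc1cc(/C=C/C(=O)C(=Cc2ccc(O)cc2)C(=O)/C=C/c2ccc(O)c(OCC)c2)ccc1O`) gives 20300 nM, the highest number of the three. Compound 4 (`CCOc1cc(/C=C/C(=O)C(=Cc2ccccc2)C(=O)/C=C/c2ccc(O)c(OCC)c2)ccc1O`) differs from compound 3 in one place: hydrogen in place of hydroxy on an aromatic carbon, so 4-hydroxyphenyl becomes phenyl. Among the compounds with values here, the one measured step on that ring, a 15-fold higher number from compound 2 to compound 3 (1.17 log units; beyond the scatter), was large, but it replaced ethoxy rather than hydroxy and so bears only indirectly. With the same phenyl, but methoxy where compound 4 has ethoxy, compound 1 gives 5450 nM. A moderate fall in the number is therefore expected in this assay, an estimated 3.4-fold lower number from compound 3 to compound 4 (0.53 log units; beyond the scatter). For compound 4 the expected value is 6000 nM, within an estimated range of 2000 nM to 18000 nM.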

Compound 4, half-maximal inhibitory concentration: 5060 nM
Compound 4: middle estimate off by 1.2-fold (0.07 log units), on the high side, and the stated range covers the measured number.
By their numbers in this assay, from the lowest: compound 2; then compounds 4 and 1 (each within the scatter of the next); then compound 3.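

Removing the hydroxy from this ring lowers the number in this assay, a 4.0-fold lower number from compound 3 to compound 4 (0.60 log units; beyond the scatter), so a lone hydroxy at this place goes with weaker inhibition. Replacing the whole 3-ethoxy-4-hydroxyphenyl with phenyl raises it, a 3.7-fold higher number from compound 2 to compound 4 (0.57 log units; beyond the scatter), so the hydroxy's effect depends on the ethoxy also being on the ring. Nothing available gives a reason for either step. The compounds shown leave open what ethoxy does on this ring without the hydroxy. They also leave open whether an amine or a fluorine at this place would behave like the hydroxy or like hydrogen.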